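Amide nitrogen variation and tolerated concentration in the series

The source may report more compounds than this note shows. Statements on the series, on what has been measured and on what is new or still open speak of the compounds shown alone.

Among the measured compounds shown here, compound 3 `O=C(CCn1cnc2cc(-c3noc(CCC4CCCC4)n3)ccc21)NC1CCCC1` is one of three compounds so far measured in a toxicity assay on HepG2 2.2.15 cells (Homo sapiens) for cytotoxicity, read by CCK-8 assay, with a stated time of 72 h; a lower number here means that less compound is tolerated, a higher number that more compound is tolerated. In this assay compound 3 gives > 20000 nM, which is a limit of the assay and not a number. Compound 2 `O=C(CCn1cnc2cc(-c3noc(CCC4CCCC4)n3)ccc21)NC1CCCCC1` gives > 20000 nM in this assay, again a limit. Compound 1 `O=C(CCn1cnc2cc(-c3noc(CCC4CCCCC4)n3)ccc21)N1CCCC1` gives > 20000 nM in this assay, also a limit. For the measured compounds named here, the only measured single change, a step that the two limits leave unreadable from compound 2 to compound 3, therefore cannot be read, and the standing of compound 3 is summed up by the limit of > 20000 nM in this assay, at which 3 of the 3 values shown sit: every value shown sits at that limit, so no measured step in this assay has a readable size or direction.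

Compound 4 `O=C(CCn1cnc2cc(-c3noc(CCC4CCCC4)n3)ccc21)N1CCCC1` differs from compound 3 in one place: pyrrolidin-1-yl in place of cyclopentylamino on a carbonyl carbon. Going by the values given here, no measured step covers this exchange; the nearest point of comparison is compound 1, which also carries pyrrolidin-1-yl on the carbonyl carbon and sits at the limit. Since none of the three values reaches a number, no step beyond the scatter is expected from compound 3 to compound 4, and the step is estimated as a step that the limit leaves unreadable from compound 3 to compound 4. Compound 4 is expected to give about 25000 nM in this assay, within 12000 nM to 50000 nM, and most likely to be reported once more only as a limit.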

Compound 4, half-maximal cytotoxic concentration: > 20000 nM
Compound 4 gave a limit, no number (the forecaster's own chance of this, stated with the estimate: 85%); the middle value does not contradict the limit.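

In this assay compound 4 gives > 20000 nM, a limit and not a number. Among the compounds shown here, no step from compound 1, compound 2 or compound 3 to compound 4 can be read. The compounds shown leave open whether any of these exchanges alters the tolerated concentration, and at what concentration any of the four would give a number: the limit of > 20000 nM in this assay, at which 4 of the 4 values shown sit.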